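Swapping the pyridine attachment point on a trifluoromethyl ketone

This account rests on a few compounds, and the source may have more. Where it says the series, first, only, none or still open, it means among the compounds named here.

Measured compounds:
- compound 1, `O=C(c1ccc(-c2nc(-c3ccccn3)no2)s1)C(F)(F)F`, 90 nM
- compound 2, `O=C(NCc1ccccc1)c1ccc(C(=O)C(F)(F)F)s1`, 243 nM
- compound 3, `O=C(c1ccc(-c2nc(-c3cccc(C(F)(F)F)c3)no2)s1)C(F)(F)F`, 320 nM

In an assay for inhibition of histone deacetylase 4 (Homo sapiens) (a lower number here means a stronger inhibitor, a higher number a weaker inhibitor), compound 1 gives 90 nM, the lowest of the three numbers. The nearest to it is compound 2, which gives 243 nM in this assay, and the furthest is compound 3 with 320 nM; both gaps lie beyond the scatter, so compound 1 is the strongest inhibitor of the three.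

Compound 4, `O=C(c1ccc(-c2nc(-c3cccnc3)no2)s1)C(F)(F)F`, keeps the shared core of compound 1 and differs from it only in the change (pyridin-3-yl in place of pyridin-2-yl on an aromatic carbon). The two have the same atoms joined differently. Going by the values given here, no directly comparable step is available among the measured compounds, so the size of this step rests on judgement alone. The step of a 1.7-fold higher number from compound 1 to compound 4 (0.22 log units; within the scatter) is expected to be small, most likely within the scatter or a modest move toward a higher number. Compound 4 is therefore expected to give 150 nM in this assay, with a likely range from 60 nM to 400 nM.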

Compound 4, half-maximal inhibitory concentration: 70 nM
For compound 4 the middle estimate is 2.1-fold (0.33 log units) above the measured one; low and high end bracket the measured number.
By their numbers in this assay, from the lowest: compounds 4 and 1 (each within the scatter of the next); then compounds 2 and 3 (each within the scatter of the next).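

In this assay, replacing pyridin-2-yl with pyridin-3-yl gives a 1.3-fold lower number from compound 1 to compound 4 (0.11 log units; within the scatter), so the two attachment points cannot be told apart at this position, on an aromatic carbon between two ring nitrogen atoms. This is the only step shown that changes a single place, and it indicates that, at least for this pair, the ring nitrogen of the pyridine can occupy either of these two places without the number moving beyond the scatter. No measured information bears on this result, and the compounds offer no explanation for it.

The compounds shown leave open whether an amine, a carboxylic acid or a morpholine ring at this same position would give a similar number in this assay. They also leave open whether this tolerance would persist if a hydroxamic acid stood in place of the trifluoromethyl ketone.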